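This account rests on a few compounds, and the source may have more. Where it says the series, first, only, none or still open, it means among the compounds named here.

Measured so far in a functional assay on ECa-109 cells (Homo sapiens) for antiproliferative activity, read by MTT assay, with a stated time of 72 h; a lower number here means a stronger inhibitor, a higher number a weaker inhibitor:
compound 1 `C#CCSc1nc(N/N=C/c2ccc(N(C)C)cc2)c2nnn(Cc3ccccc3)c2n1` gives 31300 nM
compound 2 `CCCSc1nc(N/N=C/c2ccccc2Cl)c2nnn(Cc3ccccc3)c2n1` gives 6180 nM
compound 3 `CCCSc1nc(N/N=C/c2ccc(N(C)C)cc2)c2nnn(Cc3ccccc3)c2n1` gives 20000 nM

Compound 3 stands second highest of the three numbers. Its step from compound 1, a 1.6-fold lower number from compound 1 to compound 3 (0.19 log units; within the scatter), lies within the scatter, whereas a 3.2-fold higher number from compound 2 to compound 3 (0.51 log units; beyond the scatter) lies beyond it. Compound 4 `CCCSc1nc(N/N=C/c2ccc([N+](=O)[O-])cc2)c2nnn(Cc3ccccc3)c2n1` differs from compound 3 by nitro in place of dimethylamino on an aromatic carbon. Among the measured compounds shown here, no measured step involves a nitro group. For the measured compounds named here, the only step that swaps the group on the carbon with a double bond to nitrogen, a 3.2-fold higher number from compound 2 to compound 3 (0.51 log units; beyond the scatter), was modest, so a modest step is expected here too, most likely toward a lower number in this assay, as a 2.0-fold lower number from compound 3 to compound 4 (0.30 log units; within the scatter). Compound 4 is therefore estimated at 10000 nM, with a range of 3000 nM to 30000 nM.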

Compound 4, half-maximal inhibitory concentration: 6640 nM
Beside the measured number, compound 4's estimate is 1.5-fold (0.18 log units) above it; the measured number falls inside the stated range.
By their numbers in this assay, from the lowest: compounds 2 and 4 (each within the scatter of the next); then compounds 3 and 1 (each within the scatter of the next).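

In this assay, changing only the group on the aromatic carbon moves the number beyond the scatter, with a 3.0-fold lower number from compound 3 to compound 4 (0.48 log units; beyond the scatter). With a 1.1-fold higher number from compound 2 to compound 4 (0.03 log units; within the scatter), 4-nitrophenyl and 2-chlorophenyl cannot be told apart, which leaves 4-(dimethylamino)phenyl as the one of these three aryl groups that stands apart, with the higher number. No measurement on hand explains this difference.

Still open, as far as these compounds go, is how chlorine on that same aromatic carbon would compare with nitro, since 2-chlorophenyl differs in both group and place. A methoxy group, a primary amine or a carboxylic acid there would also show whether dimethylamino alone stands apart.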